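A few compounds are considered here, and "the series" means these few. Any claim that something is new, unique, unknown or untested is made for them only; others in the source may bear on it.

Measured compounds in an assay on a protein complex for inhibition of CDK8/Cyclin C (Homo sapiens), with a stated time of 1 h, tested at 10 uM; a higher number here means more inhibition at the concentration tested (going by the name of the read-out), a lower number less inhibition:

compound 1, `O=C(/C=C/c1ccncc1-c1ccc2ncccc2c1)N1CCOCC1`, gives 80%
compound 2, `CN(C)C(=O)/C=C/c1ccncc1-c1ccc2ccccc2c1`, gives 100%
compound 3, `O=C(O)CCc1ccncc1-c1ccc2ccccc2c1`, gives 101%

Among these three numbers compound 1 stands lowest; compound 2 and compound 3 each lie beyond the usual scatter above it, and those two share a core that differs from the core of compound 1. For the measured compounds named here, the only step between measured compounds that differ in one place is a number 1 percentage points higher from compound 2 to compound 3 (within the scatter), which swaps the group on the ring carbon and leaves the reading essentially unchanged.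

Compound 4, `CNC(=O)/C=C/c1ccncc1-c1ccc2ncccc2c1`, is not yet measured. It differs from compound 1 in one place: methylamino in place of morpholin-4-yl on a carbonyl carbon. The amide is kept, but the ring on its nitrogen is replaced by a single small chain.

Going by the values given here, no measured pair isolates this exact change. Among the compounds with values here, the one available step, from the dimethylamide of compound 2 to the acid of compound 3, alters the same end of the molecule and stays within the scatter, which is the nearest guide. On that basis the reading for compound 4 is expected to stay close to that of compound 1, with a step of about a number 2 percentage points higher from compound 1 to compound 4 (within the scatter) and no clear direction. The estimate for compound 4 in this assay is 82%, with a range from 65% to 97%.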

Compound 4, a percentage reported as inhibition, at one concentration (the size of the read-out at that concentration, not a potency): 97%
For compound 4 the middle estimate is 15 percentage points below the measured one; the range from low to high includes it.
By their numbers in this assay, from the lowest: compound 1; then compounds 4, 2 and 3 (each within the scatter of the next).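

Replacing morpholin-4-yl with methylamino on the carbonyl carbon gives a number 17 percentage points higher from compound 1 to compound 4 (beyond the scatter) in this assay, so the group on this amide nitrogen can change the reading. The earlier step at this end of the molecule, a number 1 percentage points higher from compound 2 to compound 3 (within the scatter), showed no such change, although it was made on a different core and involved a different pair of groups. The new step removes the ring, reduces the group from 6 heavy atoms to 2 and adds 1 hydrogen-bond donor all at once, and nothing available here shows which of these differences matters.

The compounds shown leave open whether a slightly longer chain such as ethylamino, or a ring without the oxygen such as piperidin-1-yl, would read closer to methylamino or to morpholin-4-yl on this core. The read-out also comes from a single concentration and is not a potency, so with compound 4 at 97%, there may be little room to separate any further improvement.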